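Swapping an Aryl Ether for an Allyl Ether

The compounds below may be only part of what the source reports. "The series", "measured", "known", "first", "only" and "open" are said of these compounds alone.

Measured so far:
Compound 1, `CCC1(Cc2ccccc2)OS(=O)(=O)CC1=O`: 200000 nM
Compound 2, `CCC1(Cc2ccccc2)OS(=O)(=O)C=C1OCc1ccc(OC)cc1`: > 200000 nM
Compound 3, `CCC1(Cc2ccccc2)OS(=O)(=O)C=C1OS(=O)(=O)c1ccc(C)cc1`: 109000 nM

All three compounds share one core and were tested in an ADME assay on HEL cells (Homo sapiens) for cytotoxicity, with a stated time of 3 days; on this read-out higher numbers stand for lower toxicity in this test and lower numbers for higher toxicity in this test. In this assay compound 1 gives 200000 nM and compound 3 gives 109000 nM; these two values lie within the usual scatter of each other, so neither can be called more or less toxic than the other. For compound 2 the read-out stopped at the limit of > 200000 nM in this assay, at which 1 of the 3 values shown sits, so only a limit and no number is known for compound 2, namely > 200000 nM.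

Compound 4, `C=CCOC1=CS(=O)(=O)OC1(CC)Cc1ccccc1`, has not yet been measured. It differs from compound 2 in one place: vinyl in place of 4-methoxyphenyl on a saturated chain carbon bound to an oxygen on an unsaturated carbon. Going by the values given here, no measured pair of compounds shows this same change, so there is nothing directly to compare it with. Since all three measured values sit close together near the limit of the test, no step beyond the scatter is expected; the expected step is a number no higher from compound 2 to compound 4 (the limit leaves the size open). Compound 4 is expected to give about 200000 nM in this assay, with a range from 100000 nM to 400000 nM.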

Compound 4, half-maximal cytotoxic concentration: > 200000 nM
Compound 4 ended at the assay's limit; the forecaster's own chance of this, stated with the estimate: 50%; the middle value sits exactly at the limit.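

Going by these compounds alone, compound 2 and compound 4 both stop at a limit of the test rather than at a number, so no step between them can be read: the limit of > 200000 nM in this assay, at which 2 of the 4 values shown sit.

The compounds shown leave open whether vinyl in place of 4-methoxyphenyl changes the result in this assay at all.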